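Amide variation on a shared core, judged by paw edema

The source may report more compounds than this note shows. Statements on the series, on what has been measured and on what is new or still open speak of the compounds shown alone.

Compound 1 `COc1ccc(NC(=O)c2c(O)c3cccnc3n(-c3ccccc3)c2=O)cc1`: -1.9%
Compound 2 `O=C(Nc1ccc([N+](=O)[O-])cc1)c1c(O)c2cccnc2n(-c2ccccc2)c1=O`: -25.8%
Compound 3 `O=C(Nc1cccc([N+](=O)[O-])c1)c1c(O)c2cccnc2n(-c2ccccc2)c1=O`: 7.4%

Going by the values given here, in a functional assay on the whole organism for inhibition, with Rattus norvegicus as the target, read by cytopathic effect and paw edema, at a dose of 100 mg/kg by the oral route (on this read-out lower numbers stand for less inhibition and higher numbers for more inhibition at the one dose given (going by the name of the read-out)), compound 3 gives the highest of the three numbers, though its gap to compound 1 is within the scatter, a number 9.3 percentage points higher from compound 1 to compound 3 (within the scatter); only the step of a number 33.2 percentage points higher from compound 2 to compound 3 (beyond the scatter) lies beyond it. Compound 4 `O=C(Nc1nccs1)c1c(O)c2cccnc2n(-c2ccccc2)c1=O` differs from compound 3 by 1,3-thiazol-2-yl in place of 3-nitrophenyl on an amide-type nitrogen. Among the compounds with values here, no measured step touches a thiazolyl amide, so the only guide is that all three measured compounds sit near zero or below in this assay. Compound 4 is therefore expected to stay in that region, with a number 5.4 percentage points lower from compound 3 to compound 4 (within the scatter) not expected to exceed the scatter. The estimate for compound 4 is 2%, ranging from -22% to 24%.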

Compound 4, a percentage reported as inhibition, in the whole organism at one dose (the size of the read-out at that dose, not a potency): 2.5%
Compound 4: the middle estimate sits 0.5 percentage points below what was measured; low and high end bracket the measured number.
By their numbers in this assay, from the lowest: compound 2; then compounds 1, 4 and 3 (each within the scatter of the next).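

In this assay, 1,3-thiazol-2-yl on the amide-type nitrogen stays level with 3-nitrophenyl, a number 4.9 percentage points lower from compound 3 to compound 4 (within the scatter), and with 4-methoxyphenyl, a number 4.4 percentage points higher from compound 1 to compound 4 (within the scatter), but not with 4-nitrophenyl, a number 28.3 percentage points higher from compound 2 to compound 4 (beyond the scatter). The position is therefore not tied to a six-membered ring of carbon only, and 4-nitrophenyl alone stands apart among the four groups. Nothing at hand accounts for that separation.

From the compounds shown here alone, whether a carboxylic acid or an amine on the aromatic ring, or a plain butyl chain in its place, would lift the number clear of these values remains open.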